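A few compounds are considered here, and "the series" means these few. Any claim that something is new, unique, unknown or untested is made for them only; others in the source may bear on it.

For the measured compounds named here, compound 3 `Cc1ccc(Cl)cc1Nc1nc(C(F)(F)F)ccc1CNC(=O)C(C)c1ccc(NS(C)(=O)=O)c(F)c1` gives 140 nM in a functional assay on CHO-K1 cells for antagonist activity at transient receptor potential cation channel subfamily V member 1 (Homo sapiens), read by FLIPR (on this read-out higher numbers stand for weaker inhibition and lower numbers for stronger inhibition), the lowest of the three numbers measured so far. Compound 1 `CC1CCC(Nc2nc(C(F)(F)F)ccc2CNC(=O)C(C)c2ccc(NS(C)(=O)=O)c(F)c2)CC1` gives 1130 nM in this assay, and compound 2 `Cc1ccc(Nc2nc(C(F)(F)F)ccc2CNC(=O)C(C)c2ccc(NS(C)(=O)=O)c(F)c2)cc1C` gives 1160 nM. The three share one core and differ only in the group carried on the nitrogen attached to the aromatic ring: a 1.0-fold higher number from compound 1 to compound 2 (0.01 log units; within the scatter), whereas an 8.1-fold lower number from compound 1 to compound 3 (0.91 log units; beyond the scatter) and an 8.3-fold lower number from compound 2 to compound 3 (0.92 log units; beyond the scatter).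

Compound 4 `CC(C(=O)NCc1ccc(C(F)(F)F)nc1N(C)c1ccccc1)c1ccc(NS(C)(=O)=O)c(F)c1` has not yet been measured. It differs from compound 3 in one place: methyl(phenyl)amino in place of (5-chloro-2-methylphenyl)amino on an aromatic carbon. Going by the values given here, none of the measured steps tests this exact change; each of them kept the hydrogen on that nitrogen and only swapped the ring beyond it. Still, the two steps that end at compound 3 show that the group on this nitrogen can move the number by a fair amount, and that the 5-chloro-2-methylphenyl group stands apart from the other two groups tried. Compound 4 gives up both the chlorine and the methyl on that ring as well as the hydrogen-bond donor, so its number is expected to rise rather than fall. The expected step is an 11-fold higher number from compound 3 to compound 4 (1.03 log units; beyond the scatter), putting compound 4 roughly back at the level seen for the other two groups. Compound 4 is estimated at 1500 nM in this assay, in a range from 400 nM to 6000 nM.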

Compound 4, half-maximal inhibitory concentration: 57.4 nM
Compound 4: middle estimate off by 26-fold (1.42 log units), on the high side; measured number below the stated range.
By their numbers in this assay, from the lowest: compound 4; then compound 3; then compounds 1 and 2 (each within the scatter of the next).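

In this assay, replacing (5-chloro-2-methylphenyl)amino with methyl(phenyl)amino gives a 2.4-fold lower number from compound 3 to compound 4 (0.39 log units; beyond the scatter), so this position tolerates a group with no hydrogen-bond donor, and neither the hydrogen on the nitrogen nor the chlorine and methyl on the ring is needed for the lowest number seen in this set. For the compounds shown here, the same group also stands well apart from the other two groups tried here, with a 20-fold lower number from compound 2 to compound 4 (1.31 log units; beyond the scatter) and a 20-fold lower number from compound 1 to compound 4 (1.29 log units; beyond the scatter), which shows that the range at this position extends further than the earlier compounds suggested. No measurement shown gives a reason for these shifts in the number.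

This single change removes the ring's chlorine and methyl while also replacing the hydrogen on the nitrogen with a methyl, so the compounds shown cannot say how much each part contributes; plain phenylamino, or a methyl on the nitrogen with the 5-chloro-2-methylphenyl ring kept, would separate them. As far as these compounds go, it also remains open how the number responds to a larger group on that nitrogen, such as ethyl or a longer chain.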